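The compounds below may be only part of what the source reports. "The series", "measured", "known", "first", "only" and "open" are said of these compounds alone.

Measured in an ADME assay on J774.1 cells (Mus musculus) for cytotoxicity, read by resazurin assay, with a stated time of 48 h; a higher number here means a weaker inhibitor, a lower number a stronger inhibitor:
Compound 1 `CCCCn1cc(C(=O)O)c(=O)c2cc(F)c(Cl)cc21` gives > 100000 nM (a limit)
Compound 2 `CCCCn1cc(C(=O)O)c(=O)c2cc(F)c(N3CCC(C(N)=O)CC3)cc21` gives > 100000 nM (a limit)

Compound 2 therefore stands only at a limit of the assay, as does the other measured compound. Compound 3 `CCCCn1cc(C(=O)NCc2ccc([N+](=O)[O-])cc2)c(=O)c2cc(F)c(N3CCC(C(N)=O)CC3)cc21` differs from compound 2 by (4-nitrobenzyl)amino in place of hydroxy on a carbonyl carbon, with (4-nitrobenzyl)amino in place of hydroxy on a carbonyl carbon. Going by the values given here, the only measured step, a step that the two limits leave unreadable from compound 1 to compound 2, involves a different change and gives no size to carry over. With the limit of > 100000 nM in this assay, at which 2 of the 2 values shown sit, as the sole reference, any readable step in this assay is expected to run towards stronger inhibition. The expected step is an at least 1.6-fold lower number from compound 2 to compound 3 (0.22 log units; that floor lies within the scatter). For compound 3 the estimated value is 60000 nM, within a range of 15000 nM to 100000 nM.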

Compound 3, half-maximal inhibitory concentration: > 100000 nM
Compound 3 ended at the assay's limit (the forecaster's own chance of this, stated with the estimate: 50%); middle value at least 1.6-fold (0.22 log units) from the limit.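

Going by these compounds alone, no step from compound 2 to compound 3 can be read in this assay, since both values are limits. The compounds shown leave open what concentration, if any, would reach half-maximal inhibition of these cells for any member of the series.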